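Butyl to cyclopentyl on the amide nitrogen of a thiophene series

The source may hold more compounds than are shown below. What is called first, only, known or untested is meant among the compounds shown, and "the series" means these compounds.

Measured compounds:
compound 1 `CCCCNC(=O)c1c(N)sc(-c2ccc(Cl)cc2)c1-c1ccc(Cl)cc1` — 17800 nM
compound 2 `CS(=O)(=O)Nc1sc(-c2ccc(Cl)cc2)c(-c2ccc(Cl)cc2)c1C(=O)NC1CC1` — "not determined" (no result reported)

Among the compounds with values here, compound 1 is the only compound here with a number. In a functional assay on PC-3 cells (Homo sapiens) for inhibition, read by sulforhodamine B assay, with a stated time of 72 h (a higher number here means a weaker inhibitor, a lower number a stronger inhibitor), compound 1 gives 17800 nM, a weak result on its own. In this assay, within the data shown here, compound 2 gives "not determined" (no result reported), so it offers no point of comparison, and no step between measured compounds is available.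

Compound 3 `Nc1sc(-c2ccc(Cl)cc2)c(-c2ccc(Cl)cc2)c1C(=O)NC1CCCC1` is not yet measured. It differs from compound 1 in one place, (cyclopentyl in place of butyl on an amide-type nitrogen). The change swaps one hydrocarbon group for another of similar size, with nothing added or removed among the counted donors or acceptors. Without a measured step to lean on, the step of a 1.2-fold lower number from compound 1 to compound 3 (0.07 log units; within the scatter) is expected to stay within the usual scatter, with no direction beyond it. Compound 3 is therefore estimated at 15000 nM, with a range from 5000 nM to 45000 nM.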

Compound 3, half-maximal inhibitory concentration: 21200 nM
Beside the measured number, compound 3's estimate is 1.4-fold (0.15 log units) below it; the range from low to high includes it.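

In this assay, cyclopentyl in place of butyl on the amide-type nitrogen gives a 1.2-fold higher number from compound 1 to compound 3 (0.08 log units; within the scatter). Within the data shown here, this is the first measured step, and it shows that, at this position, an open carbon chain and a five-membered carbon ring read the same, with both compounds remaining weak inhibitors. No measurement shown here explains why these two groups read alike.

Still open, on these data alone, is whether a group of another kind on this nitrogen, such as a chain ending in an amine or a carboxylic acid, would move the number beyond the scatter. Also open, as far as these compounds go, is whether a much longer chain there, or a change elsewhere on the shared core, would do so.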